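The compounds below may be only part of what the source reports. "The series", "measured", "known", "first", "only" and "open" are said of these compounds alone.

Compound 1 `N#Cc1cc(NCc2ccccc2[N+](=O)[O-])c2cn[nH]c2c1` carries a cyano group on its core. In an assay for inhibition of Indoleamine 2,3-dioxygenase 1 (Homo sapiens), with stated times of 10 min and 60 min (on this read-out lower numbers stand for stronger inhibition and higher numbers for weaker inhibition), compound 1 gives > 100000 nM, which is a limit of the assay and not a number. Compound 2 `Cc1ccc(CNc2cc(C(F)(F)F)cc3[nH]ncc23)c([N+](=O)O)c1` and compound 3 `O=[N+]([O-])c1cc(Br)c(F)cc1CNc1cc(C(F)(F)F)cc2[nH]ncc12` share the trifluoromethyl version of the same core, each with a differently substituted side chain. In this assay compound 2 gives > 100000 nM, again a limit. Compound 3 gives > 100000 nM, likewise a limit. The whole set sits at the boundary of the assay: the limit of > 100000 nM in this assay, at which 3 of the 3 values shown sit. Compound 1 therefore stands at the same limit as the other two, and no ordering among them can be read from the numbers.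

Compound 4 `O=[N+]([O-])c1ccccc1CNc1cc(C(F)(F)F)cc2[nH]ncc12` has not yet been measured. It differs from compound 1 by trifluoromethyl in place of cyano on an aromatic carbon. Among the compounds with values here, no measured pair differs in only this one place, so no step for this change is known. On the strength of the limit of > 100000 nM in this assay, at which 3 of the 3 values shown sit, the step from compound 1 to compound 4 is expected to be a step that the limit leaves unreadable from compound 1 to compound 4, none beyond the usual scatter. Compound 4 is expected to give about 150000 nM, within a range from 50000 nM to 500000 nM, and most probably reported again only as a limit.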

Compound 4, half-maximal inhibitory concentration: 14000 nM
For compound 4 the middle estimate is 11-fold (1.03 log units) above the measured one, outside the stated range (below it).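

Within the data shown here, compound 4 is the first compound in the set to give a real number in this assay: compound 4 gives 14000 nM. Among these compounds, this makes the position on the core readable for the first time, since the earlier values were all limits and showed nothing about what this place could do. With the side chain held the same, trifluoromethyl in place of cyano on an aromatic carbon brings an at least 7.1-fold lower number from compound 1 to compound 4 (0.85 log units; beyond the scatter). The trifluoromethyl group does not yield a readable number on every side chain, since the compounds carrying it with a substituted side chain stay at the boundary of the assay: the limit of > 100000 nM in this assay, at which 3 of the 4 values shown sit.

As far as these compounds go, compound 1 gives > 100000 nM, which is a limit, so the step has a lower bound only and its full size stays unknown. From the compounds shown here alone, it also remains open whether a methyl, a chlorine, an amine or a carboxylic acid in this place would give a lower or a higher number than trifluoromethyl, and whether the step would hold with another side chain.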